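This account rests on a few compounds, and the source may have more. Where it says the series, first, only, none or still open, it means among the compounds named here.

The series rests on one shared core, seen in compound 1 `Clc1ccc2[nH]c(-c3cn(-c4ccccc4)nc3-c3ccccc3)nc2c1`. In a functional assay on MCF7 cells (Homo sapiens) for antiproliferative activity, read by MTT assay, with a stated time of 48 h (a higher number here means a weaker inhibitor, a lower number a stronger inhibitor), compound 1 gives 1960 nM. Compound 2 `Brc1ccc2[nH]c(-c3cn(-c4ccccc4)nc3-c3ccccc3)nc2c1` differs from compound 1 by bromo in place of chloro on an aromatic carbon. In this assay compound 2 gives 830 nM, and the step is a 2.4-fold lower number from compound 1 to compound 2 (0.37 log units; beyond the scatter). Compound 3 `Clc1ccc(-c2nn(-c3ccccc3)cc2-c2nc3cc(Cl)ccc3[nH]2)cc1` differs from compound 1 by chloro in place of hydrogen on an aromatic carbon. In this assay compound 3 gives 1170 nM, a step of a 1.7-fold lower number from compound 1 to compound 3 (0.22 log units; within the scatter). The numbers for compound 2 and compound 3 lie within the scatter of each other, so no order between them can be read.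

Compound 4 `Clc1ccc(-c2nn(-c3ccccc3)cc2-c2nc3cc(Br)ccc3[nH]2)cc1` has not yet been measured. It differs from compound 3 by bromo in place of chloro on an aromatic carbon, the same change that separates compound 1 from compound 2, with the surroundings of the place described in the same words for both pairs. Among these compounds the change appears twice in all, and only one instance has been measured. Going by the values given here, compound 4 is expected to show a step of a 2.1-fold lower number from compound 3 to compound 4 (0.33 log units; beyond the scatter), because the step of a 2.4-fold lower number from compound 1 to compound 2 (0.37 log units; beyond the scatter) is the only measured example of this change and is taken to carry over onto the core of compound 3. Whether it does so cannot be checked from what is in hand. The estimate for compound 4 in this assay is 550 nM, with a range from 250 nM to 1200 nM.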

Compound 4, half-maximal inhibitory concentration: 1920 nM
For compound 4 the middle estimate is 3.5-fold (0.54 log units) below the measured one, and the stated range ends below it.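

In this assay, bromo in place of chloro on the core of compound 3 gives a 1.6-fold higher number from compound 3 to compound 4 (0.22 log units; within the scatter), so no order can be read between these two compounds, and this step does not repeat the one measured on the core of compound 1: the same change on two cores in this assay, a 2.4-fold lower number (0.37 log units; beyond the scatter) from compound 1 to compound 2 and a 1.6-fold higher number (0.22 log units; within the scatter) from compound 3 to compound 4, 3.9-fold (0.59 log units) apart, beyond the scatter of two such steps. Chloro in place of hydrogen on an aromatic carbon likewise fails to repeat on the bromo-bearing core, where it gives a 2.3-fold higher number from compound 2 to compound 4 (0.36 log units; beyond the scatter): the same change on two cores in this assay, a 1.7-fold lower number (0.22 log units; within the scatter) from compound 1 to compound 3 and a 2.3-fold higher number (0.36 log units; beyond the scatter) from compound 2 to compound 4, 3.9-fold (0.59 log units) apart, beyond the scatter of two such steps. This shows that among these four compounds neither change carries from one core to the other as a fixed step, but it does not show why the two changes fail to combine, and with only one pair of steps for each change it sets no rule for any other core.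

The compounds shown carry only hydrogen, chloro or bromo at the two varied places, so it stays open how a fluoro, a methoxy or an amine at either place would read in this assay. Going by these compounds, it also stays open whether the same mismatch between cores would appear with such groups, or with a carboxylic acid on the phenyl ring that is left unchanged in all four compounds.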